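A few compounds are considered here, and "the series" means these few. Any claim that something is new, unique, unknown or untested is made for them only; others in the source may bear on it.

Compounds measured so far:
compound 1, `COc1ccc(-c2cc3ccccc3nc2/C=C/C(=O)c2ccc(O)cc2)cc1`: 3880 nM
compound 2, `COc1ccc(C(=O)/C=C/c2nc3ccccc3cc2-c2ccc(OC)cc2)cc1`: 9280 nM

In a functional assay on SK-BR-3 cells (Homo sapiens) for antiproliferative activity, read by XTT assay, with a stated time of 72 h (on this read-out higher numbers stand for weaker inhibition and lower numbers for stronger inhibition), compound 1 gives 3880 nM, while compound 2 gives 9280 nM. Within the data shown here, of the two numbers, compound 2 stands highest, the only step recorded being a 2.4-fold higher number from compound 1 to compound 2 (0.38 log units; beyond the scatter).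

Compound 3, `COc1ccc(-c2cc3ccccc3nc2/C=C/C(=O)c2ccc(OC)cc2OC)cc1`, has not yet been measured in this assay. It differs from compound 2 by methoxy in place of hydrogen on an aromatic carbon. Among the measured compounds shown here, the one measured step, from compound 1 to compound 2, concerns a different change, methyl in place of hydrogen on an oxygen, and therefore does not speak directly to adding a methoxy group on the aromatic ring. For the measured compounds named here, no measured pair shows what a second methoxy on the aryl ketone does. With nothing in the series to anchor a shift in either direction, the expectation for compound 3 is a step of a 1.0-fold lower number from compound 2 to compound 3 (0.01 log units; within the scatter), that is, no movement beyond the scatter.

Compound 3 is accordingly estimated at 9000 nM in this assay, within a range from 4000 nM to 20000 nM.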

Compound 3, half-maximal inhibitory concentration: 2260 nM
Estimate against measurement, compound 3: 4.0-fold (0.60 log units) above, outside the stated range (below it).
By their numbers in this assay, from the lowest: compounds 3 and 1 (each within the scatter of the next); then compound 2.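

In this assay, the change from 4-methoxyphenyl to 2,4-dimethoxyphenyl gives a 4.1-fold lower number from compound 2 to compound 3 (0.61 log units; beyond the scatter), the first indication that this aromatic carbon, ortho to a large group and meta to a methoxy group, responds to substitution, here in the direction of stronger inhibition. The earlier step, a 2.4-fold higher number from compound 1 to compound 2 (0.38 log units; beyond the scatter), showed only a move toward weaker inhibition on the oxygen of the same aryl ketone, whereas the ring-carbon methoxy brings the series back to the level of the hydroxyl compound, as a 1.7-fold lower number from compound 1 to compound 3 (0.23 log units; within the scatter) places these two within the scatter of each other. No data in hand explain the shift from the added methoxy.

On these data alone, the effect rests on a single pair, so it remains open whether the same methoxy would act alike on the 4-hydroxyphenyl ketone of compound 1, and whether compound 3 owes its number to the second methoxy alone. As far as these compounds go, it also remains open how this ring carbon would respond to a group other than methoxy, such as an amine, a carboxylic acid or a longer alkoxy chain.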